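Swapping a thiazole for a methoxy on the shared core

This account rests on a few compounds, and the source may have more. Where it says the series, first, only, none or still open, it means among the compounds named here.

In a functional assay on CHO cells for agonist activity at Alpha-1A adrenergic receptor (Homo sapiens), read by FLIPR and calcium flux (on this read-out lower numbers stand for smaller maximal responses and higher numbers for larger maximal responses), compound 2 `c1cc(-c2nccs2)c2c(c1)C(c1ncc[nH]1)CC2` has the higher of the two numbers, giving 64%; its nearest neighbour is compound 1 `CCCS(=O)(=O)Nc1cccc2c1CCC2c1ncc[nH]1`, which in this assay gives 54%, a gap within the scatter. Within the data shown here, the one measured step, a number 10 percentage points higher from compound 1 to compound 2 (within the scatter), exchanged a group on the same aromatic carbon. Compound 3 `COc1cccc2c1CCC2c1ncc[nH]1` arises from compound 2 by methoxy in place of 1,3-thiazol-2-yl on an aromatic carbon. Among the measured compounds shown here, no step beyond the scatter is expected here, a number 6 percentage points lower from compound 2 to compound 3 (within the scatter), because the only comparable step a number 10 percentage points higher from compound 1 to compound 2 (within the scatter) itself stayed within the scatter. Compound 3 is therefore estimated to reach 58% in this assay, with a likely range from 38% to 78%.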

Compound 3, largest response reached (Emax), in percent of the reference or control that the assay uses: 65%
Estimate against measurement, compound 3: 7 percentage points below, and the stated range covers the measured number.
By their numbers in this assay, from the lowest: compounds 1, 2 and 3 (each within the scatter of the next, the first and the last beyond it).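

In this assay methoxy, which has no ring, does as well on this aromatic carbon as the 1,3-thiazol-2-yl ring (a number 1 percentage points higher from compound 2 to compound 3 (within the scatter)). Against (propylsulfonyl)amino, methoxy gives the only step here that passes the scatter, and a modest one (a number 11 percentage points higher from compound 1 to compound 3 (beyond the scatter)), so among these three compounds a ring on this carbon is not needed for a large maximal response. Nothing available explains these numbers. Going by these compounds, whether an amine, a carboxylic acid or a longer ether chain on this carbon would keep that response remains open.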